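Ester arm variation in a kinase inhibition series

A few compounds are considered here, and "the series" means these few. Any claim that something is new, unique, unknown or untested is made for them only; others in the source may bear on it.

Measured in an assay on isolated protein for inhibition of protein kinase C zeta type (Homo sapiens), with stated times of 1 h and 2.5 min, tested at 30 uM; on this read-out lower numbers stand for less inhibition and higher numbers for more inhibition at the one concentration tested (going by the name of the read-out):
compound 1 `CCOC(=O)c1c(-c2ccc(OC)c(OC)c2)csc1NC` gives 32%
compound 2 `CCOC(=O)c1c(-c2ccc(OC)c(OC)c2)csc1N(C)C` gives 60%
compound 3 `COc1ccc(-c2csc(N)c2C(=O)OCc2ccccc2C)cc1OC` gives 64%

For the measured compounds named here, the only measured step alters the substituent on the ring nitrogen: a number 28 percentage points higher from compound 1 to compound 2 (beyond the scatter). Compound 3 shows the highest of the three numbers in this assay; its gap to compound 2 lies within the scatter, while its gap to compound 1 lies beyond it, so compound 3 and compound 2 cannot be ordered against each other.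

Compound 4 `COc1ccc(-c2csc(N)c2C(=O)OCc2ccc(C#N)cc2)cc1OC` keeps the unsubstituted nitrogen of compound 3 and changes only the ester arm: 4-cyanophenyl in place of 2-methylphenyl on a saturated chain carbon bound to an oxygen next to a carbonyl group. Going by the values given here, no measured step concerns the ester arm; the single step available concerns the nitrogen and does not bear on this change. Compounds 1, 2 and 3 carry ester arms of differing size and span the whole range of numbers seen, so nothing in the series fixes a direction for an ester change. Compound 4 is therefore expected to sit close to compound 3, with the step of a number 4 percentage points lower from compound 3 to compound 4 (within the scatter) expected to stay within the scatter. Compound 4 is estimated at 60% in this assay, with a range from 40% to 80%.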

Compound 4, a percentage reported as inhibition, at one concentration (the size of the read-out at that concentration, not a potency): 10%
Beside the measured number, compound 4's estimate is 50 percentage points above it; measured number outside the range, below it.
By their numbers in this assay, from the lowest: compound 4; then compound 1; then compounds 2 and 3 (each within the scatter of the next).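

With the unsubstituted nitrogen and the shared core held fixed, 4-cyanophenyl in place of 2-methylphenyl on a saturated chain carbon bound to an oxygen next to a carbonyl group gives a number 54 percentage points lower from compound 3 to compound 4 (beyond the scatter) in this assay. For the compounds shown here, the ester arm can therefore move this read-out by a wide margin on its own, which the earlier compounds could not show: their only one-place step, a number 28 percentage points higher from compound 1 to compound 2 (beyond the scatter), concerns the ring nitrogen. No measurement in hand accounts for the size of the new step.

As far as these compounds go, the swap removes the methyl and brings in the nitrile together, so it remains open whether the lower number follows the nitrile, the loss of the methyl or both, and an unsubstituted benzyl arm or a 4-methylbenzyl arm would help to separate these. Also open, from the compounds shown here alone, are whether the 4-cyanobenzyl arm gives a similar step on a methylamino or dimethylamino nitrogen, and how a carboxylic acid or an amide in place of the ester would read in this assay.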